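This account rests on a few compounds, and the source may have more. Where it says the series, first, only, none or still open, it means among the compounds named here.

Measured so far:
compound 1 `Cc1ccc(S(=O)(=O)c2c(O)ccc3cc(-c4cccc(O)c4)ccc23)cc1` — "not determined" (no result reported)
compound 2 `O=S(=O)(c1ccccc1)c1c(O)ccc2cc(-c3cccc(O)c3)ccc12` — "not determined" (no result reported)
compound 3 `O=C(Nc1ccccc1)c1cc2cc(-c3cccc(O)c3)ccc2cc1O` — 17%

In an in vitro assay on Sf9 cells for inhibition of 17-beta-hydroxysteroid dehydrogenase type 1 (Homo sapiens), tested at 100 nM (on this read-out higher numbers stand for a stronger effect at the one concentration tested and lower numbers for a weaker effect), compound 3 gives 17%, a weak effect. Among the measured compounds shown here, compound 2 `O=S(=O)(c1ccccc1)c1c(O)ccc2cc(-c3cccc(O)c3)ccc12` stands nowhere on the numbers: it was not measured in this assay, and neither was compound 1, so no step to or from it can be sized. Compound 4 `O=C(Nc1ccccc1)c1c(O)ccc2cc(-c3cccc(O)c3)ccc12` differs from compound 2 by phenylcarbamoyl in place of phenylsulfonyl on an aromatic carbon. With no measured starting point for compound 2, no direction for this change can be read from the data; what remains is that compound 3, which carries the same phenylcarbamoyl group on the shared core, shows only weak inhibition in this assay. Compound 4 is therefore expected to inhibit weakly as well, at an estimated 20% with a range from 0% to 50%.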

Compound 4, a percentage reported as inhibition, at one concentration (the size of the read-out at that concentration, not a potency): 40%
Compound 4: middle estimate off by 20 percentage points, on the low side; low and high end bracket the measured number.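

Compound 2 has no single number, so no step to compound 4 can be read, and nothing measured here explains the result of compound 4. As far as these compounds go, how exchanging phenylsulfonyl for phenylcarbamoyl changes inhibition stays open.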